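Exchanging One Aromatic Ring in a Cytotoxicity Series

The source may report more compounds than this note shows. Statements on the series, on what has been measured and on what is new or still open speak of the compounds shown alone.

Three compounds have been measured in a functional assay on NCI-H460 cells (Homo sapiens) for cytotoxicity, read by MTT assay, with a stated time of 72 h; on this read-out lower numbers stand for stronger inhibition and higher numbers for weaker inhibition:

Compound 1, `CN(C)CCn1cnnc1-c1cc(Oc2ccc(NC(=O)N/N=C/c3cccc(O)c3)cc2F)ccn1`, gives 780 nM.
Compound 2, `CN(C)CCn1cnnc1-c1cc(Oc2ccc(NC(=O)N/N=C/c3ccc(F)cc3Cl)cc2F)ccn1`, gives 720 nM.
Compound 3, `COc1ccc(/C=N/NC(=O)Nc2ccc(Oc3ccnc(-c4nncn4CCN(C)C)c3)c(F)c2)cc1O`, gives 620 nM.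

Compound 1 has the highest of these three numbers, but the others sit close to it: a 1.1-fold lower number from compound 1 to compound 2 (0.03 log units; within the scatter) and a 1.3-fold lower number from compound 1 to compound 3 (0.10 log units; within the scatter) are both within the scatter, so the three compounds cannot be told apart on this read-out. Compound 4, `CN(C)CCn1cnnc1-c1cc(Oc2ccc(NC(=O)N/N=C/c3c(Cl)cccc3Cl)cc2F)ccn1`, has not yet been measured. It differs from compound 1 in one place: 2,6-dichlorophenyl in place of 3-hydroxyphenyl on a carbon with a double bond to nitrogen. The 3-hydroxyphenyl leaves together with its hydrogen-bond donor and acceptor, and a 2,6-dichlorophenyl with neither enters on the carbon with a double bond to nitrogen.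

For the measured compounds named here, two measured steps bear on this, both exchanges of the same ring. a 1.1-fold lower number from compound 1 to compound 2 (0.03 log units; within the scatter) put a 2-chloro-4-fluorophenyl in that place, and a 1.2-fold lower number from compound 2 to compound 3 (0.06 log units; within the scatter) exchanged it again for a 3-hydroxy-4-methoxyphenyl; neither moved the number beyond the scatter. With a halogenated ring already giving much the same number in this place (a 1.1-fold lower number from compound 1 to compound 2 (0.03 log units; within the scatter)), compound 4 is expected to stay within the scatter of compound 1 as well. The estimate for compound 4 is 700 nM, between 350 nM and 1400 nM. This means an expected step of a 1.1-fold lower number from compound 1 to compound 4 (0.05 log units; within the scatter).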

Compound 4, half-maximal inhibitory concentration: 350 nM
For compound 4 the middle estimate is 2.0-fold (0.30 log units) above the measured one; the measured number falls inside the stated range.
By their numbers in this assay, from the lowest: compounds 4, 3, 2 and 1 (each within the scatter of the next, the first and the last beyond it).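

In this assay, for the compounds shown here, the earlier exchanges on the carbon with a double bond to nitrogen all stayed within the scatter, whereas 2,6-dichlorophenyl gives the first steps beyond it: a 2.2-fold lower number from compound 1 to compound 4 (0.35 log units; beyond the scatter) and a 2.1-fold lower number from compound 2 to compound 4 (0.31 log units; beyond the scatter). The second step shows that a halogenated ring does not by itself give this shift, since compound 2 also carries chlorine on this ring, yet the comparison with the 3-hydroxy-4-methoxyphenyl ring remains unresolved, with a 1.8-fold lower number from compound 3 to compound 4 (0.25 log units; within the scatter), so compound 4 cannot be ranked apart from compound 3. No measurement is available that explains the shift seen with compound 4.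

The compounds shown leave open whether the shift depends on chlorine itself or on the arrangement of the groups on the 2,6-dichlorophenyl ring, a question that a 2,6-difluorophenyl or 2,6-dimethylphenyl ring in the same place could help to answer. On these data alone, they also do not show how an unsubstituted phenyl or a ring bearing an amine or a carboxylic acid would behave here, so the limits of what this position tolerates remain unknown.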